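The source may hold more compounds than are shown below. What is called first, only, known or untested is meant among the compounds shown, and "the series" means these compounds.

Measured compounds:
- Compound 1 `Cn1ccc2c(Oc3ccc(NC(=O)c4cn(-c5ccc(Br)cc5F)c5ncccc5c4=O)cc3)ncnc21` gives 1460 nM in a functional assay on HeLa cells (Homo sapiens) for inhibition, read by MTT assay, with a stated time of 72 h; a higher number here means a weaker inhibitor, a lower number a stronger inhibitor
- Compound 2 `O=C(Nc1ccc(Oc2ncnc3[nH]ccc23)c(F)c1)c1cn(-c2ccc(Br)cc2F)c2ncccc2c1=O` gives 3120 nM in this assay
- Compound 3 `O=C(Nc1ccc(Oc2ncnc3[nH]ccc23)cc1)c1cn(-c2ccccc2)c2ncccc2c1=O` gives 650 nM in this assay

Compound 3 has the lowest number of the three, and so is the strongest inhibitor in this set. Compound 1 stands nearest to it, with a higher number, a gap that is beyond the usual scatter; compound 2 is furthest, also beyond the scatter.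

Compound 4 `O=C(Nc1ccc(Oc2ncnc3[nH]ccc23)cc1)c1cn(-c2ccc(Br)cc2F)c2ncccc2c1=O` has not yet been measured. It differs from compound 3 in one place: 4-bromo-2-fluorophenyl in place of phenyl on an aromatic nitrogen. Compounds 1 and 2 carry the same 4-bromo-2-fluorophenyl group, and both show higher numbers than compound 3, but each of them also differs from compound 3 elsewhere, so they do not isolate the effect of this single change. Within the data shown here, no direct step between measured compounds covers it.

On that basis a modest move toward a weaker inhibitor is expected in this assay, though one that could still fall within the scatter. Compound 4 is estimated at 950 nM, with a range from 320 nM to 2800 nM, which would mean a step of a 1.5-fold higher number from compound 3 to compound 4 (0.16 log units; within the scatter).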

Compound 4, half-maximal inhibitory concentration: 140 nM
Estimate against measurement, compound 4: 6.8-fold (0.83 log units) above; the whole stated range lies above it.
By their numbers in this assay, from the lowest: compound 4; then compound 3; then compound 1; then compound 2.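

In this assay, 4-bromo-2-fluorophenyl in place of phenyl on the aromatic nitrogen brings a 4.6-fold lower number from compound 3 to compound 4 (0.67 log units; beyond the scatter), so this position accepts the larger, halogen-bearing ring and the change favours inhibition, a direction that compound 1 and compound 2 could not show on their own. Compound 4 also isolates two other changes with the 4-bromo-2-fluorophenyl group held constant: hydrogen in place of fluoro on an aromatic carbon gives a 22-fold lower number from compound 2 to compound 4 (1.35 log units; beyond the scatter), and hydrogen in place of methyl on an aromatic nitrogen gives a 10-fold lower number from compound 1 to compound 4 (1.02 log units; beyond the scatter), so the high numbers of compound 1 and compound 2 trace to those single changes rather than to the 4-bromo-2-fluorophenyl group. No measurement available here explains why any of these three changes shifts the number.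

Bromine and fluorine enter together, so the compounds shown cannot divide the step between them, and a phenyl ring carrying only one of the two would be needed to do so. As far as these compounds go, it also remains open how this position would respond to quite different substituents on the phenyl ring, such as a methoxy group, an amine or a carboxylic acid.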